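A few compounds are considered here, and "the series" means these few. Any claim that something is new, unique, unknown or untested is made for them only; others in the source may bear on it.

Measured so far, in an in vitro functional assay on RBL cells for antagonist activity at C-C chemokine receptor type 8 (Homo sapiens), read by FLIPR and calcium flux; a lower number here means a stronger inhibitor, a higher number a weaker inhibitor:
compound 1 `COc1ccc2nccc(C3CN(C4CCN(Cc5cc6ccccc6[nH]5)CC4)C(=O)O3)c2c1` gives 25.1 nM
compound 2 `O=C1OC(c2ccnc3ccccc23)CN1C1CCN(Cc2cc3ccccc3[nH]2)CC1` gives 1000 nM
compound 3 `O=C1OC(c2ccncc2)CN1C1CCN(Cc2cc3ccccc3[nH]2)CC1` gives < 50200 nM, which is a limit of the assay and not a number the limit of < 50200 nM in this assay, at which 1 of the 3 values shown sits.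

Compound 1 holds the lowest of the two numbers in this assay; its nearest neighbour is compound 2, reached by a 40-fold higher number from compound 1 to compound 2 (1.60 log units; beyond the scatter), the change being hydrogen in place of methoxy on an aromatic carbon. The further step that the limit leaves unreadable from compound 2 to compound 3 is not readable, as compound 3 sits at a limit.

Compound 4 `COc1ccc2nccc(C3CN(C4CCN(Cc5ccc(Cl)c(Cl)c5)CC4)C(=O)O3)c2c1` is not yet measured. It differs from compound 1 by 3,4-dichlorophenyl in place of 1H-indol-2-yl on a saturated chain carbon bound to an amine nitrogen in a ring. Neither measured step touches this part of the shared core: both concern the methoxy on the aromatic ring and the quinolin-4-yl group, while the (1H-indol-2-yl)methyl group is kept in compounds 1, 2 and 3. Within the data shown here, no measured step bears directly on the change to 3,4-dichlorobenzyl, and its size and direction cannot be read from the series. As a working figure, compound 4 is expected to give 100 nM in this assay, within 15 nM to 800 nM. The step of a 4.0-fold higher number from compound 1 to compound 4 (0.60 log units; beyond the scatter) is thus expected, a moderate loss carrying wide uncertainty.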

Compound 4, half-maximal inhibitory concentration: 126 nM
For compound 4 the middle estimate is 1.3-fold (0.10 log units) below the measured one; low and high end bracket the measured number.
By their numbers in this assay, from the lowest: compound 1; then compound 4; then compound 2.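

In this assay, among these compounds, a 5.0-fold higher number from compound 1 to compound 4 (0.70 log units; beyond the scatter) is the first reading at this place, and the step is modest. The change removes the 1H-indol-2-yl group, with its five-membered aromatic ring and its hydrogen-bond donor, yet compound 4 still gives 126 nM, so the donor is not essential for nanomolar inhibition in compound 4. No measurement shown gives a reason for this step.

This single pair does not separate the loss of the 1H-indol-2-yl group from the entry of the two chlorine atoms. From the compounds shown here alone, an unsubstituted benzyl group or a 4-methoxybenzyl group on the same saturated chain carbon would help to separate them, and whether the step holds without the methoxy group of compound 1 also remains open.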